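Sulfonamide swap on two coumarin-imine cores

The source may report more compounds than this note shows. Statements on the series, on what has been measured and on what is new or still open speak of the compounds shown alone.

Compound 1 `CC(C)(C)c1cc(C(C)(C)C)c2oc(=O)c(/C=N/c3ccc(S(=O)(=O)Nc4nccs4)cc3)c(Cl)c2c1` and compound 2 `CC(C)(C)c1cc(C(C)(C)C)c2oc(=O)c(/C=N/c3ccc(S(=O)(=O)NC(=N)N)cc3)c(Cl)c2c1` share one core and differ only on a sulfonamide nitrogen. In a functional assay on MCF7 cells (Homo sapiens) for cytotoxicity, read by CCK-8 assay, with a stated time of 48 h (on this read-out lower numbers stand for stronger inhibition and higher numbers for weaker inhibition), compound 1 gives 12 nM, and compound 2 gives 18 nM. The change a group of 3 heavy atoms (1 carbon, 2 nitrogen; no ring) in place of a group of 5 heavy atoms (3 carbon, 1 nitrogen, 1 sulfur; one five-membered aromatic ring with 2 hetero atoms), on a sulfonamide nitrogen thus made a 1.5-fold higher number from compound 1 to compound 2 (0.18 log units; within the scatter), so the two values cannot be ordered.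

Compound 3 `Cc1ccc2oc(=O)c(/C=N/c3ccc(S(=O)(=O)Nc4nccs4)cc3)c(Cl)c2c1` carries a second core; the difference between the two cores is not broken down here. In this assay compound 3 gives 33 nM, which lies beyond the scatter from compound 1 but within it from compound 2.

Compound 4 `Cc1ccc2oc(=O)c(/C=N/c3ccc(S(=O)(=O)NC(=N)N)cc3)c(Cl)c2c1` is not yet measured. It arises from compound 3 by a group of 3 heavy atoms (1 carbon, 2 nitrogen; no ring) in place of a group of 5 heavy atoms (3 carbon, 1 nitrogen, 1 sulfur; one five-membered aromatic ring with 2 hetero atoms), on a sulfonamide nitrogen, the same change as from compound 1 to compound 2, at the same place. Because a 1.5-fold higher number from compound 1 to compound 2 (0.18 log units; within the scatter) stayed within the scatter, the expectation is that compound 4 moves little from compound 3, and the expected step is a 1.5-fold higher number from compound 3 to compound 4 (0.18 log units; within the scatter). This rests on one pair only, so the range is kept wide. In this assay compound 4 is expected to give 50 nM, with 20 nM to 120 nM as the expected span.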

Compound 4, half-maximal inhibitory concentration: 67 nM
Compound 4: middle estimate off by 1.3-fold (0.13 log units), on the low side, and the stated range covers the measured number.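

In this assay, putting the new group in place of 1,3-thiazol-2-yl on the sulfonamide nitrogen gives a 2.0-fold higher number from compound 3 to compound 4 (0.31 log units; beyond the scatter), a modest step in the same direction as the earlier one. Set side by side, the two steps cannot be told apart, so the change carries from the core of compound 1 to the core of compound 3 with no detectable difference in size: the same change on two cores in this assay, a 1.5-fold higher number (0.18 log units; within the scatter) from compound 1 to compound 2 and a 2.0-fold higher number (0.31 log units; beyond the scatter) from compound 3 to compound 4, 1.4-fold (0.13 log units) apart, within the scatter of two such steps. For the compounds shown here, this does not show that the step is identical on the two cores or that it would hold on a further core: it rests on two pairs in a single assay, and only one of the two steps lies beyond the scatter.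

The compounds shown leave open how other groups on the sulfonamide nitrogen, such as a methyl group, a pyridine ring or a longer alkyl chain, would compare with 1,3-thiazol-2-yl on either core. Also open is which part of the two cores sets their values apart; no step shown breaks that difference down.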